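The source may hold more compounds than are shown below. What is called first, only, known or untested is meant among the compounds shown, and "the series" means these compounds.

Compound 1 `Cc1nc(N)c2c(-c3ccccc3)cn([C@@H]3O[C@H](CO)[C@@H](O)[C@H]3O)c2n1` and compound 2 `Cc1nc(N)c2c(-c3cccs3)cn([C@@H]3O[C@H](CO)[C@@H](O)[C@H]3O)c2n1` share one core and differ only at the aromatic carbon that carries the pendant ring; compound 3 `COc1ncnc2c1c(-c1cccs1)cn2[C@@H]1O[C@H](CO)[C@@H](O)[C@H]1O` is built on a second core, and the difference between the two cores is not broken down here. In a functional assay on CEM-DNR-bulk cells (Homo sapiens), read by MTT assay, with a stated time of 72 h (on this read-out higher numbers stand for weaker inhibition and lower numbers for stronger inhibition), compound 1 gives only a limit of the assay, > 20000 nM. Compound 2 likewise gives only a limit in this assay, > 20000 nM. The change from compound 2 to compound 1 is phenyl in place of thiophen-2-yl on an aromatic carbon; its size stays unreadable, a step that the two limits leave unreadable from compound 2 to compound 1, because the limit of > 20000 nM in this assay, at which 2 of the 3 values shown sit, holds both values at the same edge. Among the compounds with values here, compound 3 is the one compound with a number in this assay, 12100 nM. Compound 4 `COc1ncnc2c1c(-c1ccccc1)cn2[C@@H]1O[C@H](CO)[C@@H](O)[C@H]1O`, not yet measured, stands to compound 3 as compound 1 stands to compound 2: the change is the same, (phenyl in place of thiophen-2-yl on an aromatic carbon), made at a place described in the same words. The earlier step gives no size to carry over. Compound 4 is expected to show a step of a 1.2-fold higher number from compound 3 to compound 4 (0.06 log units; within the scatter) within scatter, that expectation resting on the unreadable earlier step and on compound 3 at 12100 nM. Compound 4 is estimated at 14000 nM, between 6000 nM and 30000 nM.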

Compound 4, half-maximal inhibitory concentration: > 20000 nM
Compound 4 was reported as a limit; the forecaster's own chance of this, stated with the estimate: 30%; middle value at least 1.4-fold (0.15 log units) from the limit.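

In this assay, phenyl in place of thiophen-2-yl on the core of compound 3 gives an at least 1.6-fold higher number from compound 3 to compound 4 (0.21 log units; that floor lies within the scatter), which is only a floor, so the change is shown neither to lie beyond the scatter nor to stay within it. As far as these compounds go, compound 4 is a limit of the assay and not a number, so the true size of this step stays open. The same change on the core of compound 1 and compound 2 cannot be read, and carrying it from one core to the other is neither confirmed nor refuted, because the values rest at one edge: the limit of > 20000 nM in this assay, at which 3 of the 4 values shown sit.

Compound 3 alone carries a number, so the compounds shown give no measured size for the change on either core and no ranking of the two pendant rings. Open too, from the compounds shown here alone, is whether an amine, a carboxylic acid or a longer chain on that aromatic carbon would give a number in this assay instead of a limit.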